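Swapping chloro for sulfanyl on an aromatic carbon

A few compounds are considered here, and "the series" means these few. Any claim that something is new, unique, unknown or untested is made for them only; others in the source may bear on it.

Of the compounds shown here, three have been tested in a functional assay on L1210 cells (Mus musculus) for inhibition (a higher number here means a weaker inhibitor, a lower number a stronger inhibitor), so far, and only one gave a number. Compound 1 `C=C1[C@H](n2ccc(=O)[nH]c2=O)O[C@H](CO)[C@H]1O` is reported only as the limit > 500000 nM and not as a number. Compound 2 `C=C1[C@@H](O)[C@H](n2cnc3c(SC)nc(N)nc32)O[C@@H]1CO` is likewise reported only as the limit > 500000 nM in this assay and not as a number. Compound 3 `C=C1[C@H](n2cnc3c(Cl)nc(N)nc32)O[C@H](CO)[C@H]1O` is the only one with a measured half-maximal inhibitory concentration, and compound 3 gives 10000 nM in this test.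

Compound 4 `C=C1[C@H](n2cnc3c(S)nc(N)nc32)O[C@H](CO)[C@H]1O` differs from compound 3 in one place. The change is sulfanyl in place of chloro on an aromatic carbon and in words it is sulfanyl in place of chloro on an aromatic carbon, next to the ring nitrogen.

Within the data shown here, no measured pair of compounds differs in one place, so the data give no direct guide to the size of this step. The expectation therefore starts from compound 3 at 10000 nM alone, and it leans modestly toward stronger inhibition in this assay with a wide margin on both sides. The expected change is a 3.3-fold lower number from compound 3 to compound 4 (0.52 log units; beyond the scatter) and this estimate is a loose one. For compound 4 the estimated value is 3000 nM with an expected range from 300 nM to 60000 nM in this test.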

Compound 4, half-maximal inhibitory concentration: 20000 nM
For compound 4 the middle estimate is 6.7-fold (0.82 log units) below the measured one; the range from low to high includes it.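

In this assay, among these compounds, sulfanyl in place of chloro on this aromatic carbon, next to the ring nitrogen, gives a 2.0-fold higher number from compound 3 to compound 4 (0.30 log units; within the scatter), so the two compounds cannot be told apart and this is the first single-place step that can be read. It shows that this position can carry either of these two single-atom groups without a difference beyond the scatter, even though sulfanyl brings a hydrogen-bond donor and a hydrogen-bond acceptor that chloro lacks. Neither compound 3 nor compound 4 sits at the ceiling of this assay, so both give real numbers where the other compounds of the series give only a limit: the limit of > 500000 nM in this assay, at which 2 of the 4 values shown sit.

What the compounds shown leave open is whether this carbon accepts groups beyond these two, such as an amine, a hydroxyl or a methoxy, with the same lack of effect on the read-out. A single step on one core also cannot say whether the same swap would behave alike on any other compound in the series.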